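Swapping a chlorine for a pyridine ring on an aryl ether core

The source may report more compounds than this note shows. Statements on the series, on what has been measured and on what is new or still open speak of the compounds shown alone.

Compound 2 `CC1(c2ccc(Cl)cc2)CC(S(=O)(=O)c2ccc(F)cc2)=C(c2ccc(/C(N)=N\O)cc2)O1` has the higher of the two numbers measured in an ADME assay on HepG2 cells (Homo sapiens) for cytotoxicity, read by MTT assay, with a stated time of 72 h (on this read-out higher numbers stand for lower toxicity in this test and lower numbers for higher toxicity in this test), where compound 2 gives 61400 nM. Its nearest neighbour is compound 1 `CC1(c2ccc(-c3ccc(/C(N)=N\O)cc3)cc2)CC(S(=O)(=O)c2ccc(F)cc2)=C(c2ccc(/C(N)=N\O)cc2)O1`, which in this assay gives 15300 nM. Within the data shown here, the one change between them, one chlorine atom in place of a larger aromatic group, gave a 4.0-fold higher number from compound 1 to compound 2 (0.60 log units; beyond the scatter). Compound 3 `CC1(c2ccc(-c3ccncc3)cc2)CC(S(=O)(=O)c2ccc(F)cc2)=C(c2ccc(/C(N)=N\O)cc2)O1` takes that same chlorine away again and puts (pyridin-4-yl in place of chloro on an aromatic carbon). Among the measured compounds shown here, only the step from compound 1 to compound 2 speaks to this exchange, and it runs the opposite way: removing an aromatic ring raised the number, so restoring one is expected to lower it by a modest amount. For compound 3 the estimate is therefore 25000 nM, with a range from 10000 nM to 60000 nM, amounting to an expected step of a 2.5-fold lower number from compound 2 to compound 3 (0.39 log units; beyond the scatter).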

Compound 3, half-maximal cytotoxic concentration: 30300 nM
The estimate for compound 3 lay 1.2-fold (0.08 log units) below the measured number; the range from low to high includes it.
By their numbers in this assay, from the lowest: compounds 1 and 3 (each within the scatter of the next); then compound 2.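

In this assay, pyridin-4-yl on this aromatic carbon gives a 2.0-fold lower number from compound 2 to compound 3 (0.31 log units; beyond the scatter), so a second compound now shows an aromatic ring here going with a lower number than chloro. The step of a 2.0-fold higher number from compound 1 to compound 3 (0.30 log units; within the scatter) means that pyridin-4-yl and the larger ring-bearing group of compound 1 cannot be told apart in this test, and chloro in compound 2 is the only group shown that stands clear of both. Nothing measured here explains why the number shifts with these groups.

The compounds shown leave open whether the ring itself goes with the lower number, since a plain phenyl ring at this position would test that directly. They also leave open where a small non-ring group, such as methoxy or an amine, would fall relative to chloro.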